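A few compounds are considered here, and "the series" means these few. Any claim that something is new, unique, unknown or untested is made for them only; others in the source may bear on it.

Measured compounds in an assay on A549 cells for inhibition of transcription factor p65 (Homo sapiens), read by fluorescence, with a stated time of 2 h; a lower number here means a stronger inhibitor, a higher number a weaker inhibitor:

Compound 1, `COc1ccc(/C=C/C(=O)c2cccc(-c3cccc(F)c3)c2)cc1`. In this assay compound 1 reaches only the limit > 50000 nM and gives no number.

Compound 2, `COc1cc(/C=C/C(=O)c2ccc(N)c(-c3ccc(F)cc3)c2)cc(OC)c1OC`. In this assay compound 2 gives 11600 nM.

Compound 3, `COc1ccc(/C=C/C(=O)c2cccc(-c3cccc(F)c3)c2)cc1OC`. In this assay compound 3 gives 33400 nM.

From compound 3 to compound 1 the change is hydrogen in place of methoxy on an aromatic carbon. That step is an at least 1.4-fold higher number from compound 3 to compound 1 (0.17 log units; that floor lies within the scatter), and its size is only a floor because of the limit of > 50000 nM in this assay, at which 1 of the 3 values shown sits. How the core of compound 2 differs from the core of compound 3 is not broken down here; the two values show compound 2 with the lower number, and the gap between them lies beyond the scatter.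

Compound 4, `COc1ccc(/C=C/C(=O)c2ccc(N)c(-c3ccc(F)cc3)c2)cc1OC`, is not yet measured. From compound 2 to compound 4 the change is hydrogen in place of methoxy on an aromatic carbon. The surroundings are not the same word for word: in compound 2 the carbon that loses the methoxy is also meta to a methoxy group, which is not so in compound 3, so this is the same kind of change rather than the same change.

Compound 4 is expected to show a step of a 2.5-fold higher number from compound 2 to compound 4 (0.40 log units; beyond the scatter), a step at least as large as the earlier one, because an at least 1.4-fold higher number from compound 3 to compound 1 (0.17 log units; that floor lies within the scatter) gives only a floor and the true step there may be wider. In this assay compound 4 is expected to give about 29000 nM, estimated between 12000 nM and 80000 nM.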

Compound 4, half-maximal inhibitory concentration: > 50000 nM
Compound 4 gave a limit, no number; the forecaster's own chance of this, stated with the estimate: 30%; middle value at least 1.7-fold (0.23 log units) from the limit.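

The same replacement of methoxy by hydrogen, carried onto the second core, gives an at least 4.3-fold higher number from compound 2 to compound 4 (0.63 log units; beyond the scatter) in this assay, so on this core the loss of the methoxy group shows up as a weaker inhibitor by a margin that clears the scatter. Across the two cores the direction is compatible with a single trend, since neither pair moves towards a lower number, but the sizes are floors and no true size can be compared, so this does not show that the change transfers with the same magnitude, nor that it is larger on the core of compound 2: the same change on two cores in this assay, an at least 1.4-fold higher number (0.17 log units; that floor lies within the scatter) from compound 3 to compound 1 and an at least 4.3-fold higher number (0.63 log units; beyond the scatter) from compound 2 to compound 4; the limit leaves it open whether they differ. Among these compounds, with only two pairs, and an upper end missing from both steps, any statement on transfer stays limited to these four compounds, and the assay ceiling restricts what further reading is possible: the limit of > 50000 nM in this assay, at which 2 of the 4 values shown sit.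

Left open is how this carbon responds when something other than hydrogen replaces the methoxy group, for example a hydroxyl group or a longer ethoxy chain. Also open is whether the step keeps its direction on cores beyond the two shown here.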